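The compounds below may be only part of what the source reports. "The series", "measured", "known", "first", "only" and "open" are said of these compounds alone.

Measured in a functional assay on the whole organism for antagonist activity, with Mus musculus as the target; on this read-out higher numbers stand for an effect only at larger amounts of compound and lower numbers for an effect already at smaller amounts:

- Compound 1 `CC(=O)NCC(=O)N(C)c1ccc(Cl)cc1C(=O)c1ccccc1Cl` gives 2.3 mg/kg
- Compound 2 `CN1CCN(CC(=O)NCC(=O)N(C)c2ccc(Cl)cc2C(=O)c2ccccc2Cl)CC1` gives 59 mg/kg
- Compound 3 `CN(C(=O)CNC(=O)c1ccccc1)c1ccc(Cl)cc1C(=O)c1ccccc1Cl` gives 2.9 mg/kg

Two of these values cannot be told apart, as the measurements show a 1.3-fold higher number from compound 1 to compound 3 (0.10 log units; within the scatter). The remaining gap is much wider, at a 20-fold lower number from compound 2 to compound 3 (1.31 log units; beyond the scatter). Compound 3 therefore sits in the low-number pair, where less compound is needed for the effect.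

The next compound is compound 4 `CN(C(=O)CNC(=O)c1ccccc1)c1ccc(Cl)cc1C(=O)c1ccccc1`. It keeps everything in compound 3 except for hydrogen in place of chloro on an aromatic carbon, ortho to a large group: hydrogen in place of chloro on an aromatic carbon. In other words, 2-chlorophenyl becomes phenyl.

For the measured compounds named here, no measured step touches this chloro, so the evidence is only indirect. All three steps alter the other end of the molecule. Exchanging methyl for phenyl gave a 1.3-fold higher number from compound 1 to compound 3 (0.10 log units; within the scatter), whereas adding 4-methylpiperazin-1-yl gave a 26-fold higher number from compound 1 to compound 2 (1.41 log units; beyond the scatter). The change here removes a single heavy atom, so a jump of that larger size seems unlikely. A modest move towards a higher number is expected, although no measurement supports that direction, and the range is kept wide. The estimated step is a 2.4-fold higher number from compound 3 to compound 4 (0.38 log units; beyond the scatter). For compound 4 the estimate is 7 mg/kg, with an expected range from 2.5 mg/kg to 25 mg/kg.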

Compound 4, dose for half-maximal effect: 7.6 mg/kg
The estimate for compound 4 lay 1.1-fold (0.04 log units) below the measured number; the measured number falls inside the stated range.
By their numbers in this assay, from the lowest: compounds 1 and 3 (each within the scatter of the next); then compound 4; then compound 2.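

In this assay, hydrogen in place of chloro gives a 2.6-fold higher number from compound 3 to compound 4 (0.42 log units; beyond the scatter), the only step shown at this end of the molecule, and it lies beyond the scatter. So the chloro of the 2-chlorophenyl group is not a silent passenger: with plain phenyl in its place, a larger dose is needed for the same effect. The step is still modest beside a 26-fold higher number from compound 1 to compound 2 (1.41 log units; beyond the scatter) at the other end of the molecule, and nothing measured here explains why this single atom counts.

At this place on the ring, only chloro and hydrogen are shown, so it remains open how a fluoro, bromo, methyl or methoxy group would compare with them. Going by these compounds, it is also open whether the same exchange of chloro for hydrogen would give a step of similar size on compound 1 or compound 2, whose other ends differ, or whether its effect holds only alongside the benzoyl group of compound 3.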